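The compounds below may be only part of what the source reports. "The series", "measured", "known", "first", "only" and "open" are said of these compounds alone.

Compound 1 `ClCc1cccc(Cn2cnc3ncnc(Cl)c32)c1` is the starting point of this step. In a functional assay on NCI-H322M cells (Homo sapiens) for cytotoxicity, read by sulforhodamine B assay, with a stated time of 48 h (a lower number here means a stronger inhibitor of growth, a higher number a weaker inhibitor of growth), compound 1 gives 3460 nM. Two close relatives have been measured in the same way: compound 2 `ClCc1cccc(Cn2cnc3c(Cl)ncnc32)c1` gives 3460 nM, and compound 3 `ClCc1cccc(Cn2cnc3c(Cl)nc(Cl)nc32)c1` gives 5120 nM. Compound 1 therefore stands level with compound 2 at the digits shown, and its gap to compound 3 is within the usual scatter of this kind of measurement, so the three numbers cannot be told apart with confidence.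

The new compound is compound 4 `ClCc1cccc(Cn2cnc3nc(Cl)nc(Cl)c32)c1`. It differs from compound 1 in one place: chloro in place of hydrogen on an aromatic carbon.

Going by the values given here, one measured step bears directly on this change, since it is the same kind of replacement on the shared core: a 1.5-fold higher number from compound 2 to compound 3 (0.17 log units; within the scatter). That step stayed within the scatter, giving no sign that adding a chloro group in this manner shifts the number in either direction.

On that basis the step from compound 1 to compound 4 is expected to be small, a 1.3-fold higher number from compound 1 to compound 4 (0.11 log units; within the scatter), with no change beyond the scatter. For compound 4 the estimated number in this assay is 4500 nM, with a likely range from 2000 nM to 10000 nM.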

Compound 4, concentration for total growth inhibition: 26900 nM
The estimate for compound 4 lay 6.0-fold (0.78 log units) below the measured number; the whole stated range lies below it.
By their numbers in this assay, from the lowest: compounds 1, 2 and 3 (each within the scatter of the next); then compound 4.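

In this assay, placing a chloro group on the aromatic carbon between two ring nitrogen atoms is not a neutral change on the core of compound 1: a 7.8-fold higher number from compound 1 to compound 4 (0.89 log units; beyond the scatter), and a higher number here means a weaker inhibitor of growth. The earlier pair gave no sign of this, and the two cores clearly respond differently to the same replacement: the same change on two cores in this assay, a 1.5-fold higher number (0.17 log units; within the scatter) from compound 2 to compound 3 and a 7.8-fold higher number (0.89 log units; beyond the scatter) from compound 1 to compound 4, 5.3-fold (0.72 log units) apart, beyond the scatter of two such steps. This position therefore cannot be judged from the change alone, since the same swap of hydrogen for chloro stays within the scatter on one core and goes beyond it on the other, so the core that carries the group matters.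

The compounds shown leave open whether the weaker inhibition belongs to the chloro group itself or would follow from other groups at this place, such as an amine or a methoxy group, since only hydrogen and chloro are seen there. They also leave open what in the two cores makes the same replacement count for so much more on one than on the other.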